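The compounds below may be only part of what the source reports. "The series", "measured", "known", "first", "only" and "open" are said of these compounds alone.

Working notes on the series. Compound 1 `Cc1ccc(-c2ccccc2NCC2=NCCN2)n1C` and compound 2 `Cn1cccc1-c1ccccc1NCC1=NCCN1` share one core. Going by the values given here, in a functional assay with Alpha-1D adrenergic receptor (Homo sapiens) as the target, read by calcium flux (a lower number here means a smaller maximal response, a higher number a larger maximal response), compound 1 gives 0%, and compound 2 gives 32%; the single measured step, a number 32 percentage points higher from compound 1 to compound 2 (beyond the scatter), follows a hydrogen in place of methyl on an aromatic carbon. Among the compounds with values here, compound 2 therefore stands highest of the two numbers, with compound 1 as its only neighbour, lower by a step beyond the scatter.

Compound 3 `CCn1cccc1-c1ccccc1NCC1=NCCN1` is not yet measured. It differs from compound 2 by methyl in place of hydrogen on a saturated chain carbon bound to an aromatic nitrogen. Within the data shown here, no measured step touches this place: the one step known, from compound 1 to compound 2, concerns an aromatic carbon, so it bears on the present change only loosely, and the series gives no second case of methyl to ethyl. The only direction seen so far is that the compound carrying the extra methyl, compound 1, sits lower, so a modest drop is expected for compound 3 in this assay, with the change estimated as a number 12 percentage points lower from compound 2 to compound 3 (beyond the scatter). Compound 3 is estimated at 20%, within a range of 0% to 45%.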

Compound 3, largest response reached (reported as maximal response), in percent of the reference or control that the assay uses: 0%
Beside the measured number, compound 3's estimate is 20 percentage points above it; measured number inside the range.
By their numbers in this assay, from the lowest: compounds 1 and 3 (each within the scatter of the next); then compound 2.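

In this assay, the saturated chain carbon bound to an aromatic nitrogen proves to be a sensitive place: methyl to ethyl there gives a number 32 percentage points lower from compound 2 to compound 3 (beyond the scatter). Going by these compounds alone, this is the first measured step at this position, and it matches in size a number 32 percentage points higher from compound 1 to compound 2 (beyond the scatter), so in this small set a single methyl more or less at either of two different places separates compound 2 from a compound with no recorded response. The data shown offer no measurement that accounts for this drop.

Still open, from the compounds shown here alone, is whether a longer chain such as propyl, or a hydroxyethyl group, on the aromatic nitrogen would also leave no response. A maximal response alone also leaves open how compound 3 would behave in a read-out of potency or of blockade at this receptor.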